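The compounds below may be only part of what the source reports. "The series", "measured", "known", "first", "only" and "open" are said of these compounds alone.

Among the measured compounds shown here, in a toxicity assay on L02 cells (Homo sapiens) for cytotoxicity, read by MTT assay, with a stated time of 72 h (on this read-out lower numbers stand for stronger inhibition and higher numbers for weaker inhibition), compound 1 (`O=C1c2c[n+]([O-])c3ccccc3c2C(=O)c2c1c1ccccc1n2CCCCN1CCNCC1`) gives 1380 nM, and compound 2 (`CN1CCN(CCCn2c3c(c4ccccc42)C(=O)c2c[n+]([O-])c4ccccc4c2C3=O)CC1`) gives 230 nM, the lower of the two numbers so far. Compound 3 (`O=C1c2c[n+]([O-])c3ccccc3c2C(=O)c2c1c1ccccc1n2Cc1cn(C[C@@H](O)CO)nn1`) remains unmeasured and differs from compound 2 as follows: 1-(2,3-dihydroxypropyl)-1H-1,2,3-triazol-4-yl in place of 2-(4-methylpiperazin-1-yl)ethyl on a saturated chain carbon bound to an aromatic nitrogen. For the measured compounds named here, the only measured step, a 6.0-fold lower number from compound 1 to compound 2 (0.78 log units; beyond the scatter), lies beyond the scatter and also alters the chain group, but no measured compound carries the entering triazole, so it offers only a rough guide to size. A step of similar or somewhat larger size towards a higher number is expected in this assay. The expected change is a 6.5-fold higher number from compound 2 to compound 3 (0.81 log units; beyond the scatter). For compound 3 the estimated value is 1500 nM, with an expected range of 400 nM to 6000 nM.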

Compound 3, half-maximal inhibitory concentration: 490 nM
Estimate against measurement, compound 3: 3.1-fold (0.49 log units) above; measured number inside the range.
By their numbers in this assay, from the lowest: compound 2; then compound 3; then compound 1.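

In this assay, the saturated chain carbon bound to an aromatic nitrogen accepts a group without a piperazine ring: 1-(2,3-dihydroxypropyl)-1H-1,2,3-triazol-4-yl gives a 2.1-fold higher number from compound 2 to compound 3 (0.33 log units; beyond the scatter), and a 2.8-fold lower number from compound 1 to compound 3 (0.45 log units; beyond the scatter). The number for compound 3 thus falls inside the span set by the two piperazine-bearing compounds. Nothing available explains either step.

As far as these compounds go, whether the triazole ring or the dihydroxypropyl part drives these steps remains open. So does where a morpholine or a dimethylamino group on the chain would fall.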